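This account rests on a few compounds, and the source may have more. Where it says the series, first, only, none or still open, it means among the compounds named here.

Among the compounds with values here, in an assay on Sf9 cells for inhibition of mitogen-activated protein kinase kinase kinase 14 variant S549D (Homo sapiens), with a stated time of 30 min, in the presence of a further agent that is not named here (on this read-out higher numbers stand for weaker inhibition and lower numbers for stronger inhibition), compound 1 `C=CC(=O)NCC#Cc1ccc2ncn(-c3ccnc(N)n3)c2c1` gives 6310 nM, and compound 2 `C=Cc1nccc(C#Cc2ccc3ncn(-c4ccnc(N)n4)c3c2)n1` gives 39800 nM, the higher of the two numbers measured so far; the only step recorded is a 6.3-fold higher number from compound 1 to compound 2 (0.80 log units; beyond the scatter), in which a group of 8 heavy atoms (6 carbon, 2 nitrogen; one six-membered aromatic ring with 2 hetero atoms) took the place of a group of 6 heavy atoms (4 carbon, 1 nitrogen, 1 oxygen; no ring) on a triple-bonded carbon.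

Compound 3 `C#Cc1cncc(C#Cc2ccc3ncn(-c4ccnc(N)n4)c3c2)n1` differs from compound 2 by a group of 8 heavy atoms (6 carbon, 2 nitrogen; one six-membered aromatic ring with 2 hetero atoms) in place of a group of 8 heavy atoms (6 carbon, 2 nitrogen; one six-membered aromatic ring with 2 hetero atoms), on a triple-bonded carbon: the group that leaves carries 1 double bond outside aromatic rings, the group that enters carries 1 triple bond outside aromatic rings, each with 0 hydrogen-bond donors and 2 hydrogen-bond acceptors, at a triple-bonded carbon whose other neighbour is a triple-bonded carbon. Within the data shown here, no measured step bears directly on this exchange of one ring-bearing group for another of the same size; the one step on record concerned a change of a different kind. The expected step of a 1.1-fold lower number from compound 2 to compound 3 (0.06 log units; within the scatter) is therefore put at none beyond the scatter. On that basis compound 3 is expected to give about 35000 nM in this assay, within a range from 12000 nM to 100000 nM.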

Compound 3, half-maximal inhibitory concentration: 6310 nM
Compound 3: middle estimate off by 5.5-fold (0.74 log units), on the high side, and the stated range ends above it.
By their numbers in this assay, from the lowest: compounds 1 and 3 (each within the scatter of the next); then compound 2.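

In this assay, exchanging one ring-bearing group on the triple-bonded carbon for another gives a 6.3-fold lower number from compound 2 to compound 3 (0.80 log units; beyond the scatter), so at this place two groups that match in heavy atoms, hydrogen-bond donors and hydrogen-bond acceptors are still not interchangeable, the one with 1 double bond outside aromatic rings and the one with 1 triple bond outside aromatic rings reading differently. The earlier step from the ring-free group to a ring-bearing one had raised the number, but that rise does not hold for every ring-bearing group: the other such change reads no change at the digits printed from compound 1 to compound 3 (within the scatter), which leaves the group with no ring and the ring-bearing group with the triple bond level within the scatter. No measurement at hand accounts for the difference between the two ring-bearing groups.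

The compounds shown leave open whether the gap follows the triple bond itself or the different arrangement of atoms within the two rings, since both change together in this exchange. They also leave open how this read-out would respond to the same ring carrying a nitrile or an amine in place of the double or triple bond.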